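Swapping an Oxygen-Bearing Ring for an All-Carbon Side Chain

A few compounds are considered here, and "the series" means these few. Any claim that something is new, unique, unknown or untested is made for them only; others in the source may bear on it.

Going by the values given here, in an assay on CHO cells for displacement of a labelled ligand from histamine receptor H3 (Macaca mulatta) (on this read-out lower numbers stand for stronger inhibition and higher numbers for weaker inhibition), compound 2 `Cc1cc(NC(=O)C2CCOCC2)ccc1N1CCC(N2CCCC2C)C1` gives 17 nM, the lowest of the two numbers measured so far. Compound 1 `Cc1cc(NC(=O)C2CC3CCC2C3)ccc1N1CCC(N2CCCC2C)C1` gives 130 nM, and the step of a 7.6-fold lower number from compound 1 to compound 2 (0.88 log units; beyond the scatter) shows that moving to the oxygen-containing ring was favourable. Compound 3 `Cc1cc(NC(=O)CC2CCCC2)ccc1N1CCC(N2CCCC2C)C1` differs from compound 2 by cyclopentylmethyl in place of oxan-4-yl on a carbonyl carbon. This change removes the oxygen and returns to an all-carbon group, echoing the measured step in reverse, so a weakening beyond the scatter is expected, though a smaller one, as the group stays similar in size. Compound 3 is therefore estimated at 60 nM, between 25 nM and 200 nM, an expected step of a 3.5-fold higher number from compound 2 to compound 3 (0.55 log units; beyond the scatter).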

Compound 3, inhibition constant: 10.7 nM
Estimate against measurement, compound 3: 5.6-fold (0.75 log units) above; the whole stated range lies above it.
By their numbers in this assay, from the lowest: compounds 3 and 2 (each within the scatter of the next); then compound 1.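

Taking the ring oxygen out at this place on the carbonyl carbon has no measurable cost in this assay: cyclopentylmethyl in place of oxan-4-yl gives a 1.6-fold lower number from compound 2 to compound 3 (0.20 log units; within the scatter), so that oxygen is not needed for this level of binding. All-carbon groups are therefore not weak as a class here, as the other all-carbon group shows in a 12-fold lower number from compound 1 to compound 3 (1.08 log units; beyond the scatter) at this same place. Nothing available explains why these two all-carbon groups differ so widely. Still open, going by these compounds, is whether a ring nitrogen, as in piperidin-4-yl, or a longer chain such as 2-cyclopentylethyl would keep these numbers.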